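Chloro Substitution on a Quinazoline Hydrazone Series

This account rests on a few compounds, and the source may have more. Where it says the series, first, only, none or still open, it means among the compounds named here.

Of the compounds shown here, three of this set have been measured in a functional assay on HT-29 cells (Homo sapiens) for cytotoxicity, read by MTT assay, with a stated time of 72 h; on this read-out lower numbers stand for stronger inhibition and higher numbers for weaker inhibition. Compound 1 `CN(C)CCNc1nc(N/N=C/c2ccc(F)cc2)nc2ccccc12` gives 1530 nM in this assay. Compound 2 `CN(C)CCNc1nc(N/N=C/c2ccc(F)cc2Cl)nc2ccccc12` gives 330 nM. Compound 3 `CN(C)CCCNc1nc(N/N=C/c2ccc(F)cc2)nc2ccccc12` gives 870 nM, and compound 4 `CN(C)CCCNc1nc(N/N=C/c2ccc(F)cc2Cl)nc2ccccc12` has not yet been measured.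

From compound 1 to compound 2 the change is chloro in place of hydrogen on an aromatic carbon. That step in this assay is a 4.6-fold lower number from compound 1 to compound 2 (0.67 log units; beyond the scatter). From compound 1 to compound 3 the cores differ by (dimethylamino)methyl in place of dimethylamino on a saturated chain carbon, two bonds along the chain from a nitrogen on an aromatic ring, a step of a 1.8-fold lower number from compound 1 to compound 3 (0.25 log units; within the scatter), so compound 1 and compound 3 cannot be told apart with confidence in this assay.

Compound 4 differs from compound 3 by chloro in place of hydrogen on an aromatic carbon. Within the data shown here, this is the same change as the one from compound 1 to compound 2, made on a different core: the place is described in the same words in both pairs, and the cores differ only by (dimethylamino)methyl in place of dimethylamino on a saturated chain carbon, two bonds along the chain from a nitrogen on an aromatic ring. An effect of similar direction and size is expected on the core of compound 3 because a 4.6-fold lower number from compound 1 to compound 2 (0.67 log units; beyond the scatter) lies beyond the scatter. Compound 3 is thus estimated to give the step of a 4.4-fold lower number from compound 3 to compound 4 (0.64 log units; beyond the scatter). Among the measured compounds shown here, compound 4 is therefore expected to show about 200 nM in this assay, with an estimated range from 80 nM to 500 nM, resting on compound 3 at 870 nM and on the single measured step from compound 1 to compound 2.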

Compound 4, half-maximal inhibitory concentration: 1150 nM
Estimate against measurement, compound 4: 5.8-fold (0.76 log units) below; the measured number lies above the stated range.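

With a 1.3-fold higher number from compound 3 to compound 4 (0.12 log units; within the scatter) in this assay, the change from 4-fluorophenyl to 2-chloro-4-fluorophenyl did not carry over from the core of compound 1 to the core of compound 3: the same change on two cores in this assay, a 4.6-fold lower number (0.67 log units; beyond the scatter) from compound 1 to compound 2 and a 1.3-fold higher number (0.12 log units; within the scatter) from compound 3 to compound 4, 6.1-fold (0.79 log units) apart, beyond the scatter of two such steps

The difference between the two amine side chains, read on the chloro-bearing pair as a 3.5-fold higher number from compound 2 to compound 4 (0.54 log units; beyond the scatter), likewise depends on what else the compound carries: the same change on two cores in this assay, a 1.8-fold lower number (0.25 log units; within the scatter) from compound 1 to compound 3 and a 3.5-fold higher number (0.54 log units; beyond the scatter) from compound 2 to compound 4, 6.1-fold (0.79 log units) apart, beyond the scatter of two such steps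

So in these four compounds the two changes do not act independently of each other, but this rests on a single pair per core in one assay, and it does not show why the steps differ or how far the dependence reaches beyond compound 1, compound 2, compound 3 and compound 4.

The compounds shown leave open whether a bromo or a methyl group in place of the chloro would follow the large step seen on the core of compound 1 or the step within the scatter seen on the core of compound 3. They also leave open how a longer chain, or a morpholine in place of the dimethylamino group, would behave with and without the chloro.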